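Replacing the side chain of compound 1

The source may report more compounds than this note shows. Statements on the series, on what has been measured and on what is new or still open speak of the compounds shown alone.

Compound 1 `COCCNc1cc(Oc2c(C)cc(/C=C/C#N)cc2C)nc(Nc2ccc(C#N)cc2)n1` gives 3190 nM
Compound 2 `Cc1cc(/C=C/C#N)cc(C)c1Oc1cc(Nc2ccc(C#N)cc2)nc(NC2CC2)c1` gives 24800 nM

In an ADME assay on MT4 cells (Homo sapiens) for cytotoxicity, read by MTT assay, with a stated time of 5 days (on this read-out lower numbers stand for higher toxicity in this test and higher numbers for lower toxicity in this test), compound 1 stands lowest of the two at 3190 nM and compound 2 lies at 24800 nM beyond the scatter. Compound 3 `Cc1cc(/C=C/C#N)cc(C)c1Oc1cc(NCC2CCCO2)nc(Nc2ccc(C#N)cc2)n1` carries oxolan-2-yl in place of methoxymethyl on a saturated chain carbon bound to a nitrogen on an aromatic ring. Among the compounds with values here, no measured pair shows this change alone, so only a small move toward a higher number in this assay is expected, probably within the scatter. The estimated step is a 1.4-fold higher number from compound 1 to compound 3 (0.15 log units; within the scatter) at most modest. Compound 3 is expected at 4500 nM (estimated range 1500 nM to 15000 nM).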

Compound 3, half-maximal cytotoxic concentration: > 268000 nM
Compound 3 ended at the assay's limit; the forecaster's own chance of this, stated with the estimate: 10%; middle value at least 59-fold (1.77 log units) from the limit.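

In this assay, the side chain of compound 1 proves far from indifferent: exchanging methoxymethyl for oxolan-2-yl on the saturated chain carbon gives an at least 84-fold higher number from compound 1 to compound 3 (1.92 log units; beyond the scatter). Compound 3 gives > 268000 nM, which is a limit of the assay and not a number. This step therefore has a lower bound only, and its true size stays unknown: the limit of > 268000 nM in this assay, at which 1 of the 3 values shown sits.

The compounds shown leave open whether the ring or its oxygen accounts for the step. A cyclopentyl or pyrrolidin-2-yl group at the same place would separate the two.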